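A few compounds are considered here, and "the series" means these few. Any claim that something is new, unique, unknown or untested is made for them only; others in the source may bear on it.

Measured so far in a functional assay, read by spectrophotometry, with a stated time of 3 min; a lower number here means a stronger inhibitor, a higher number a weaker inhibitor:
compound 1 `O=c1cc(/C=N\c2ccc(O)cc2)c2c(OCc3ccccc3)cc(OCc3ccccc3)cc2o1` gives 3570 nM
compound 2 `O=c1cc(/C=N\Nc2ccc([N+](=O)[O-])cc2[N+](=O)[O-])c2c(OCc3ccccc3)cc(OCc3ccccc3)cc2o1` gives "not active" (no number reported)
compound 3 `Nc1ccccc1/N=C\c1cc(=O)oc2cc(OCc3ccccc3)cc(OCc3ccccc3)c12` gives 7530 nM

Compound 3 stands highest of the two numbers obtained. Its nearest neighbour is compound 1, and the step of a 2.1-fold higher number from compound 1 to compound 3 (0.32 log units; beyond the scatter) lies beyond the scatter, so compound 3 is the weaker of the two. Compound 2 returned no number and is recorded as inactive.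

Compound 4 `O=c1cc(/C=N\Nc2ccccc2)c2c(OCc3ccccc3)cc(OCc3ccccc3)cc2o1` differs from compound 3 in one place: anilino in place of 2-aminophenyl on a double-bonded nitrogen. Among the compounds with values here, the only measured step that alters the group on the double-bonded nitrogen is a 2.1-fold higher number from compound 1 to compound 3 (0.32 log units; beyond the scatter), and it is modest. Within the data shown here, no measured pair tests the exchange of a directly attached aryl ring for an anilino group; the sole compound carrying a nitrogen-linked group at this position, compound 2, gave no number in this assay, which is a warning rather than a trend.

On that basis a change for compound 4 of roughly the size seen between compounds 1 and 3 is expected, direction uncertain but leaning weaker given compound 2. The expected step is a 1.5-fold higher number from compound 3 to compound 4 (0.16 log units; within the scatter). Compound 4 is estimated at 11000 nM, with a range of 3500 nM to 40000 nM, and a real chance of no number being obtained.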

Compound 4, half-maximal inhibitory concentration: 40100 nM
The estimate for compound 4 lay 3.6-fold (0.56 log units) below the measured number; the whole stated range lies below it.
By their numbers in this assay, from the lowest: compound 1; then compound 3; then compound 4.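

In this assay, the group on the double-bonded nitrogen matters more than the earlier pair indicated: replacing 2-aminophenyl with anilino gives a 5.3-fold higher number from compound 3 to compound 4 (0.73 log units; beyond the scatter), a larger change than a 2.1-fold higher number from compound 1 to compound 3 (0.32 log units; beyond the scatter), and replacing 4-hydroxyphenyl with anilino gives an 11-fold higher number from compound 1 to compound 4 (1.05 log units; beyond the scatter), a large step. Compound 4 has the highest number of the three compounds with values, yet it does give a number, so a nitrogen-linked group at this position is compatible with measurable inhibition, although compound 2 returned none. Within the data shown here, nothing measured here explains why the exchange of these two groups, which match in the counts computed for them, shifts the number so far.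

The compounds shown leave open whether the higher number of compound 4 follows from the nitrogen link itself or from the lack of a substituent on its ring, a question that plain phenyl, 4-hydroxyanilino and 2-aminoanilino at this position would separate. They also leave open how groups without an aromatic ring behave here, such as a simple alkyl amine or a chain ending in a carboxylic acid.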